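Amino in place of methyl at a limit

The source may hold more compounds than are shown below. What is called first, only, known or untested is meant among the compounds shown, and "the series" means these compounds.

In a functional assay on KYSE-70 cells for antiproliferative activity against KYSE-70 cell line (Homo sapiens), read by MTT assay, with a stated time of 72 h (on this read-out higher numbers stand for weaker inhibition and lower numbers for stronger inhibition), compound 1 (`O=C(Nc1cccc(F)c1)c1cc(=O)[nH]c2cc(-c3ccc(F)cc3)ccc12`) gives 3300 nM. Compound 2 (`CC(=O)c1ccc(-c2ccc3c(C(=O)Nc4cccc(F)c4)cc(=O)[nH]c3c2)cc1`) gives only a limit, > 20000 nM. From the compounds shown here alone, compound 3 (`Cc1ccc(-c2ccc3c(C(=O)Nc4cccc(F)c4)cc(=O)[nH]c3c2)cc1`) also gives only a limit, > 20000 nM, so its true position is unknown. Compound 4 (`Nc1ccc(-c2ccc3c(C(=O)Nc4cccc(F)c4)cc(=O)[nH]c3c2)cc1`) differs from it by amino in place of methyl on an aromatic carbon, with amino in place of methyl on an aromatic carbon. The steps bearing on this are an at least 6.0-fold higher number from compound 1 to compound 3 (0.78 log units; beyond the scatter) and an at least 6.0-fold higher number from compound 1 to compound 2 (0.78 log units; beyond the scatter), while a step that the two limits leave unreadable from compound 2 to compound 3 gives no size. Only the fluoro compound has so far given a number, so a modest move toward lower numbers is expected, though a second limit remains possible. The expected step is an at least 2.0-fold lower number from compound 3 to compound 4 (0.30 log units; that floor lies within the scatter). Compound 4 is estimated at 10000 nM, within an expected range of 2500 nM to 30000 nM.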

Compound 4, half-maximal inhibitory concentration: > 20000 nM
Compound 4 ended at the assay's limit; the forecaster's own chance of this, stated with the estimate: 40%; middle value at least 2.0-fold (0.30 log units) away from the limit.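

In this assay, amino at this place, para to a large group, brings no readable gain over methyl: compound 4 gives > 20000 nM, which is a limit of the assay. Amino in place of fluoro gives an at least 6.0-fold higher number from compound 1 to compound 4 (0.78 log units; beyond the scatter), so a group bringing a hydrogen-bond donor joins acetyl and methyl in giving no measured number. Among these four compounds, only compound 1, with fluoro, has a number: the limit of > 20000 nM in this assay, at which 3 of the 4 values shown sit.

From the compounds shown here alone, the steps among compound 2, compound 3 and compound 4 cannot be read, so their order remains unknown. Going by these compounds, whether chloro or hydroxyl at this place would give a number also remains open.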